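The compounds below may be only part of what the source reports. "The series", "measured", "known", "first", "only" and "open" are said of these compounds alone.

Working notes on the series. In a functional assay on U-251 cells (Homo sapiens) for inhibition, read by sulforhodamine B assay, with a stated time of 72 h (on this read-out higher numbers stand for an effect only at larger amounts of compound and lower numbers for an effect already at smaller amounts), compound 1 `O=C(/C=C/c1ccc([N+](=O)[O-])o1)c1ccc(Br)cc1` gives 21400 nM. Compound 2 `CSc1ccc(C(=O)/C=C/c2ccc([N+](=O)[O-])o2)cc1` gives 14200 nM, and compound 3 `CC(C)(C)c1ccc(C(=O)/C=C/c2ccc([N+](=O)[O-])o2)cc1` gives 44500 nM, the highest of the three numbers. Compound 1 therefore stands in a narrow range, with its nearest neighbour at a 1.5-fold lower number from compound 1 to compound 2 (0.18 log units; within the scatter) and its furthest at a 2.1-fold higher number from compound 1 to compound 3 (0.32 log units; beyond the scatter).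

The unmeasured compound 4 `O=C(/C=C/c1ccc([N+](=O)[O-])o1)c1ccc(-n2ccnc2)cc1` differs from compound 1 by 1H-imidazol-1-yl in place of bromo on an aromatic carbon. The three measured steps are swaps on that same aromatic carbon. The largest of them is a 3.1-fold higher number from compound 2 to compound 3 (0.50 log units; beyond the scatter), which is still modest. Among the compounds with values here, none of the measured compounds carries a ring in this group, so the direction of the change remains open and the range stays wide.

The step expected in this assay is a 1.2-fold lower number from compound 1 to compound 4 (0.08 log units; within the scatter), so no shift beyond the scatter is expected. For compound 4 the estimated value is 18000 nM, with an expected range from 6000 nM to 50000 nM.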

Compound 4, half-maximal effective concentration: 22600 nM
Estimate against measurement, compound 4: 1.3-fold (0.10 log units) below; measured number inside the range.
By their numbers in this assay, from the lowest: compounds 2, 1, 4 and 3 (each within the scatter of the next, the first and the last beyond it).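

In this assay a group with a ring, 1H-imidazol-1-yl, with 5 heavy atoms and 2 hydrogen-bond acceptors, can replace the single bromine atom on this aromatic carbon with a 1.1-fold higher number from compound 1 to compound 4 (0.02 log units; within the scatter) as the result. The other two steps, a 2.0-fold lower number from compound 3 to compound 4 (0.29 log units; within the scatter) and a 1.6-fold higher number from compound 2 to compound 4 (0.20 log units; within the scatter), also stay within the scatter, so compound 4 lies within the scatter of compounds 1, 2 and 3, although compounds 2 and 3 lie beyond it from each other. Nothing available bears on why the ring-bearing group reads so close to the others.

Going by these compounds, whether an amine, a carboxylic acid or a longer chain on this carbon would move the number beyond the scatter stays open. On these data alone, all four compounds share the rest of the core, so the effect of changes elsewhere also stays open.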